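Shrinking the hydroxylated ring on the carbonyl carbon: solubility

The source may report more compounds than this note shows. Statements on the series, on what has been measured and on what is new or still open speak of the compounds shown alone.

In a physicochemical assay for solubility, read by HPLC, using the shake flask method, in phosphate buffer, with a stated time of 2 h, at pH 6.5 (on this read-out lower numbers stand for lower solubility and higher numbers for higher solubility), the measured compounds stand as follows:

compound 1 `Nc1ncc(-c2ccc(C(=O)N3CCC(O)CC3)cc2)nc1-c1ccc(C(F)(F)F)cc1`: 19000 nM
compound 2 `Nc1ncc(-c2ccc(C(=O)N3CC[C@H](O)C3)cc2)nc1-c1ccc(C(F)(F)F)cc1`: 68000 nM
compound 3 `CNC(=O)c1ccc(-c2nc(-c3ccc(C(N)=O)cc3)cnc2N)cc1`: 178000 nM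

Compound 1 holds the lowest number of the three; compound 2 is nearest and compound 3 furthest, with the highest value shown. Compound 4 `Nc1ncc(-c2ccc(C(=O)N3CC(O)C3)cc2)nc1-c1ccc(C(F)(F)F)cc1` differs from compound 1 by 3-hydroxyazetidin-1-yl in place of 4-hydroxypiperidin-1-yl on a carbonyl carbon. Within the data shown here, the one measured step that bears on this is a 3.6-fold higher number from compound 1 to compound 2 (0.55 log units; beyond the scatter), a contraction of the same ring on the same carbonyl carbon; compound 4 carries that contraction further. Compound 3 differs from compound 1 in several places and gives no guide. A step in this assay of similar or somewhat larger size in the same direction is therefore expected, a 3.7-fold higher number from compound 1 to compound 4 (0.57 log units; beyond the scatter). For compound 4 the estimate is 70000 nM, with a range from 25000 nM to 200000 nM.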

Compound 4, solubility: 55000 nM
Beside the measured number, compound 4's estimate is 1.3-fold (0.10 log units) above it; measured number inside the range.
By their numbers in this assay, from the lowest: compound 1; then compounds 4 and 2 (each within the scatter of the next); then compound 3.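

Contraction to 3-hydroxyazetidin-1-yl on a carbonyl carbon keeps the gain over 4-hydroxypiperidin-1-yl, seen as a 2.9-fold higher number from compound 1 to compound 4 (0.46 log units; beyond the scatter) in this assay and the further contraction adds to it nothing that can be read: a 1.2-fold lower number from compound 2 to compound 4 (0.09 log units; within the scatter) leaves compound 2 and compound 4 level. Among these three compounds the number therefore does not rise with each contraction of the ring. Nothing available explains this flattening.

Open, as far as these compounds go, is how much of the gain depends on the hydroxyl, which plain azetidin-1-yl or a 3-aminoazetidin-1-yl group would test. Also open, from the compounds shown here alone, is whether an open-chain hydroxyethyl amide on the same carbonyl carbon would follow the rings.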